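The source may hold more compounds than are shown below. What is called first, only, known or untested is meant among the compounds shown, and "the series" means these compounds.

Compound 1 `OC[C@H]1O[C@@H](n2cnc3c(NCc4ccc(Cl)c(Cl)c4)ncnc32)[C@H](O)[C@@H]1O`: 145000 nM
Compound 2 `COc1cc(CNc2ncnc3c2ncn3[C@@H]2O[C@H](CO)[C@@H](O)[C@H]2O)cc(OC)c1`: "not determined" (no result reported)

In a functional assay on G-361 cells (Homo sapiens) for antiproliferative activity, with a stated time of 72 h (a higher number here means a weaker inhibitor, a lower number a stronger inhibitor), compound 2 has no number, its entry reading "not determined" (no result reported). Compound 3 `OC[C@H]1O[C@@H](n2cnc3c(NCc4c(F)ccc(F)c4F)ncnc32)[C@H](O)[C@@H]1O` has not yet been measured. The change, (2,3,6-trifluorophenyl in place of 3,5-dimethoxyphenyl on a saturated chain carbon bound to a nitrogen on an aromatic ring), puts 2,3,6-trifluorophenyl in place of 3,5-dimethoxyphenyl on a saturated chain carbon bound to a nitrogen on an aromatic ring. Within the data shown here, no step from compound 2 can be sized in this assay, so the expectation rests on compound 1 alone, at 145000 nM. Compound 3 is expected to remain a weak inhibitor, though moderately stronger than that single reference. Compound 3 is estimated at 40000 nM, within an expected range of 5000 nM to 170000 nM.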

Compound 3, half-maximal inhibitory concentration: > 166000 nM
Compound 3 ended at the assay's limit; the forecaster's own chance of this, stated with the estimate: 35%; middle value at least 4.1-fold (0.61 log units) away from the limit.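

In this assay, compound 3 gives > 166000 nM, which is a limit of the assay and not a number. The replacement of 3,4-dichlorophenyl by 2,3,6-trifluorophenyl on a saturated chain carbon bound to a nitrogen on an aromatic ring gives an at least 1.1-fold higher number from compound 1 to compound 3 (0.05 log units; that floor lies within the scatter), so this change shows no strengthening at this position. How far compound 3 lies beyond compound 1 cannot be read: the limit of > 166000 nM in this assay, at which 1 of the 3 values shown sits.

Steps involving compound 2 cannot be read. Going by these compounds, it remains open whether an amine or a carboxylic acid on the phenyl ring, or a longer chain in place of the saturated chain carbon, would bring a stronger value.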